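Amide to Urea on a Shared Core

The source may hold more compounds than are shown below. What is called first, only, known or untested is meant among the compounds shown, and "the series" means these compounds.

Compound 1 `COc1cc(-c2nn(-c3cccc(NC(=O)c4ccc(Cl)c(C(F)(F)F)c4)c3)cc2-c2ccncc2)ccc1Cl`: > 32500 nM
Compound 2 `O=C(Nc1cccc(-n2cc(-c3ccncc3)c(-c3ccc(Cl)c(O)c3)n2)c1)Nc1cc(C(F)(F)F)cc(C(F)(F)F)c1`: 4370 nM

In a functional assay on PC-3 cells (Homo sapiens) for inhibition, read by sulforhodamine B assay, with a stated time of 48 h (on this read-out higher numbers stand for weaker inhibition of growth and lower numbers for stronger inhibition of growth), compound 1 reaches only a limit, > 32500 nM. Compound 1 therefore sits at the limit of > 32500 nM in this assay, at which 1 of the 2 values shown sits. Among the measured compounds shown here, compound 2 gives 4370 nM in this assay; its core differs from that of compound 1, so no single step joins them. Compound 3 `COc1cc(-c2nn(-c3cccc(NC(=O)Nc4cccc(C(F)(F)F)c4)c3)cc2-c2ccncc2)ccc1Cl` keeps the core of compound 1 and changes the carbonyl: (3-(trifluoromethyl)phenyl)amino in place of 4-chloro-3-(trifluoromethyl)phenyl on a carbonyl carbon. Compound 2 also bears an amino group on its carbonyl and yields a number rather than a limit. Compound 3 is expected near 15000 nM, between 3000 nM and 40000 nM. The expected step is an at least 2.1-fold lower number from compound 1 to compound 3 (0.33 log units; beyond the scatter), toward stronger inhibition, with much uncertainty.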

Compound 3, concentration for total growth inhibition: 2510 nM
Estimate against measurement, compound 3: 6.0-fold (0.78 log units) above; the measured number lies below the stated range.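

With the shared core held fixed, changing the group on the carbonyl carbon gives an at least 12-fold lower number from compound 1 to compound 3 (1.11 log units; beyond the scatter) in this assay, so this position clearly affects growth inhibition. The change turns the amide into a urea and also removes the chlorine. The full size of the step cannot be read because compound 1 is only a limit: the limit of > 32500 nM in this assay, at which 1 of the 3 values shown sits.

As far as these compounds go, whether the added amino link or the lost chlorine matters more remains open. So does how a cyclohexylamino group on the same carbonyl carbon would read.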